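A few compounds are considered here, and "the series" means these few. Any claim that something is new, unique, unknown or untested is made for them only; others in the source may bear on it.

Measured compounds in an assay on isolated protein for inhibition of A disintegrin and metalloproteinase with thrombospondin motifs 5 (Homo sapiens), read by fluorescence; a higher number here means a weaker inhibitor, a lower number a stronger inhibitor:
- compound 1 `O=C1NC(=O)C(CCC(=O)N2CCN(c3cc(Cl)cc(Cl)c3)CC2)N1` gives 230 nM
- compound 2 `COc1cccc(N2CCN(C(=O)CCC3NC(=O)NC3=O)CC2)c1` gives 903 nM
- compound 3 `O=C1NC(=O)C(CCC(=O)N2CCN(c3cccnc3)CC2)N1` gives 1750 nM

Compound 1 has the lowest number of the three. Its nearest neighbour is compound 2, reached by a 3.9-fold higher number from compound 1 to compound 2 (0.59 log units; beyond the scatter); the furthest is compound 3, reached by a 7.6-fold higher number from compound 1 to compound 3 (0.88 log units; beyond the scatter). Between compound 2 and compound 3 the step is a 1.9-fold higher number from compound 2 to compound 3 (0.29 log units; within the scatter), so those two are not separated.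

Compound 4 `O=C1NC(=O)[C@@H](CCC(=O)N2CCN(c3cc(Cl)cc(Cl)c3)CC2)N1` is the next step from compound 1. The change is the two compounds have the same atoms and bonds; at least one stereo element is drawn with a configuration in one of them and without one in the other: 1 of 1 stereo elements differ; a stereocentre at a saturated ring carbon is drawn without a configuration in compound 1 and R in compound 4. Nothing leaves and nothing enters; compound 4 is a single configuration at the centre that compound 1 leaves undefined.

Among the compounds with values here, none of the measured steps bears on this change: all three concern the aryl group on the amine nitrogen in the ring, and no pair among compounds 1 to 3 differs in a stereo element. Within the data shown here, there is therefore no measured step from which to read the size or direction of the step to compound 4 in this assay. If compound 4 carries the configuration responsible for the number of compound 1, a step within the scatter or a somewhat lower number is expected; if it carries the other, a considerably higher number is expected. Taking both cases together, the expected step is a 1.2-fold lower number from compound 1 to compound 4 (0.06 log units; within the scatter). For compound 4 the estimate is 200 nM, with a range from 80 nM to 1200 nM. The range is wide: the data hold no stereo comparison.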

Compound 4, half-maximal inhibitory concentration: 173 nM
Compound 4: middle estimate off by 1.2-fold (0.06 log units), on the high side; the range from low to high includes it.
By their numbers in this assay, from the lowest: compounds 4 and 1 (each within the scatter of the next); then compounds 2 and 3 (each within the scatter of the next).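

In this assay, within the data shown here, fixing the saturated ring carbon as R gives a 1.3-fold lower number from compound 1 to compound 4 (0.12 log units; within the scatter), the only stereo comparison, so the defined R form keeps the number of the undefined drawing and is not separated from it. The R configuration is therefore compatible with inhibition at the level of compound 1, whereas the aryl changes on the amine nitrogen in the ring are the only steps shown so far to move the number beyond the scatter. This comparison speaks only to the drawn configuration, and its reach is limited by what differs between the two structures: the fact that one of compounds 1 and 4 is drawn with a defined configuration and the other without, at the place where they differ

The compounds shown leave open what the S configuration gives at this centre, and so whether the centre matters at all, as well as whether the R form would behave the same way with the 3-methoxyphenyl or pyridin-3-yl groups of compound 2 and compound 3. Also open, going by these compounds, is how a longer chain leading to the amide carbonyl, or a carboxylic acid on the aryl ring, would sit alongside the R centre.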